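This account rests on a few compounds, and the source may have more. Where it says the series, first, only, none or still open, it means among the compounds named here.

Measured so far in a functional assay on Huh-7 cells (Homo sapiens) for cytotoxicity, read by MTT assay, with a stated time of 72 h (on this read-out higher numbers stand for lower toxicity in this test and lower numbers for higher toxicity in this test), all as limits of the assay:
compound 1 `CCCCS(=O)(=O)N1CCC2(CC1)OOC1(CCCC1)OO2` gives > 100 ug/mL as a limit
compound 2 `O=S(=O)(CCCCl)N1CCC2(CC1)OOC1(CCCC1)OO2` gives > 100 ug/mL as a limit
compound 3 `Cc1ccc(S(=O)(=O)N2CCC3(CC2)OOC2(CCCC2)OO3)cc1` gives > 100 ug/mL as a limit

Compound 3 stands at > 100 ug/mL as a limit and not a number. Among the compounds with values here, the series so far rests on the limit of > 100 ug/mL in this assay, at which 3 of the 3 values shown sit, and offers no measured number.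

The change to compound 4 `COc1ccc(S(=O)(=O)N2CCC3(CC2)OOC2(CCCC2)OO3)cc1` is methoxy in place of methyl on an aromatic carbon and reads in short as methoxy in place of methyl on an aromatic carbon, para to a large group.

Within the data shown here, no measured step makes this exact change. The nearest are a step that the two limits leave unreadable from compound 1 to compound 3 and a step that the two limits leave unreadable from compound 2 to compound 3 and both are changes on a sulfonyl sulfur. The step that the two limits leave unreadable from compound 1 to compound 2 adds little more. With no readable size among them, no step beyond the scatter is expected in this assay in either direction. The estimated change is a step that the limit leaves unreadable from compound 3 to compound 4 and it may well stay hidden behind a limit. Compound 4 is expected near 150 ug/mL with an estimated range of 80 ug/mL to 300 ug/mL and a report as a limit is the likeliest outcome.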

Compound 4, half-maximal cytotoxic concentration: > 100 ug/mL
Compound 4: no number, only a limit; the forecaster's own chance of this, stated with the estimate: 85%; the middle value does not contradict the limit.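

No new step can be read among compound 1, compound 2, compound 3 and compound 4, because all four rest on the same limit: the limit of > 100 ug/mL in this assay, at which 4 of the 4 values shown sit. The compounds shown leave open the size of any effect on cytotoxicity from changes on the sulfonyl sulfur or the aromatic carbon.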